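This account rests on a few compounds, and the source may have more. Where it says the series, first, only, none or still open, it means among the compounds named here.

Compound 1 `CCN(CC)c1ccc2cc(C(=O)c3ccc(N4CCN(C(=O)CN5CCN(Cc6ccc(/C=C/C(=O)OC)cc6)CC5)CC4)cc3)oc2c1` and compound 2 `CCN(CC)c1ccc2cc(C(=O)c3ccc(N4CCN(C(=O)CN5CCN(Cc6ccc(C#N)cc6)CC5)CC4)cc3)oc2c1` share one core and differ at a single aromatic carbon. In an ADME assay on L02 cells (Homo sapiens) for cytotoxicity, read by MTT assay, with a stated time of 48 h (a lower number here means a stronger inhibitor, a higher number a weaker inhibitor), compound 1 gives > 100000 nM, which is a limit of the assay and not a number. In this assay compound 2 gives 29600 nM. Among the compounds with values here, the only measured step, an at least 3.3-fold lower number from compound 1 to compound 2 (0.52 log units; beyond the scatter), is bounded on one side by the limit of > 100000 nM in this assay, at which 1 of the 2 values shown sits. Among the values shown, compound 2 therefore stands as the only true number, the other being a limit.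

Compound 3 `CCN(CC)c1ccc2cc(C(=O)c3ccc(N4CCN(C(=O)CN5CCN(CC(C)=O)CC5)CC4)cc3)oc2c1` has not been measured. Its change from compound 2 is acetyl in place of 4-cyanophenyl on a saturated chain carbon bound to an amine nitrogen in a ring. Within the data shown here, the single measured step concerns the same region of the molecule and shows that a change there can move the number beyond the scatter, though it exchanged one substituent on the aromatic ring rather than removing the ring altogether. Among the measured compounds shown here, with no measured step that removes the ring, the expectation rests loosely on that step alone, and a modest move toward a higher number is expected, as a 2.0-fold higher number from compound 2 to compound 3 (0.31 log units; beyond the scatter). For compound 3 the estimated value in this assay is 60000 nM, expected to fall between 20000 nM and 150000 nM.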

Compound 3, half-maximal inhibitory concentration: > 100000 nM
Compound 3 was reported as a limit; the forecaster's own chance of this, stated with the estimate: 40%; middle value at least 1.6-fold (0.22 log units) from the limit.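

In this assay, an at least 3.3-fold higher number from compound 2 to compound 3 (0.52 log units; beyond the scatter), so at this saturated chain carbon bound to an amine nitrogen in a ring, replacing the whole 4-cyanophenyl group with acetyl moves the number beyond the scatter, and the true size of that move stays hidden on one side. The earlier step exchanged only a substituent on the aromatic ring, whereas this one shows that a change removing the ring also leads away from the one true number among the compounds shown, that of compound 2, and this is the only comparison here in which the ring is lost. Compound 3 and compound 1 both end at a limit and not a number, so the step between them cannot be read and neither can be ranked against the other: the limit of > 100000 nM in this assay, at which 2 of the 3 values shown sit.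

The compounds shown leave open whether the nitrile or the aromatic ring itself matters for the number of compound 2, since the step to compound 3 replaces both together. A plain benzyl group, or an amine or a longer chain in place of acetyl, could separate these possibilities and show whether this position can give a true number lower than that of compound 2.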